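The compounds below may be only part of what the source reports. "The series", "measured", "known", "first", "only" and "open" are said of these compounds alone.

In an ADME assay (liver) for metabolic stability, with Liver microsome (Rattus norvegicus) as the target, using microsomes and NADPH, with a stated time of 30 min, tested at 1 uM (a higher number here means faster removal of the compound, a lower number slower removal), compound 1 `COc1cc(C(O)(C(F)(F)F)C(F)(F)F)cnc1N1CCN(S(=O)(=O)c2ccc(N)nc2)CC1` gives < 14 mL.min-1.g-1, and this figure is a limit of the assay, not a measured number. Compound 2 `Nc1ccc(S(=O)(=O)N2CCN(c3ncc(C(O)(C(F)(F)F)C(F)(F)F)cc3-c3ccncc3)CC2)cn1`, with pyridin-4-yl in place of methoxy, gives 31 mL.min-1.g-1. Compound 3 `Nc1ccc(S(=O)(=O)N2CCN(c3ncc(C(O)(C(F)(F)F)C(F)(F)F)cc3-c3ccc4scnc4c3)CC2)cn1`, with 1,3-benzothiazol-5-yl at that same place, gives 147 mL.min-1.g-1, the highest number of the three and so the fastest removal. The measured steps show how far this one place can move the number: an at least 10-fold higher number from compound 1 to compound 3 (1.02 log units; beyond the scatter) is a large step, and a 4.7-fold higher number from compound 2 to compound 3 (0.68 log units; beyond the scatter) is a modest one beyond the scatter.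

Compound 4 `Cc1nc2cc(-c3cc(C(O)(C(F)(F)F)C(F)(F)F)cnc3N3CCN(S(=O)(=O)c4ccc(N)nc4)CC3)ccc2o1` changes the same place again, with 2-methyl-1,3-benzoxazol-5-yl in place of 1,3-benzothiazol-5-yl on an aromatic carbon. Among the measured compounds shown here, no measured step swaps one such two-ring group for another, so those steps show only that this place matters, not what this exchange will do. Both groups have one five-membered aromatic ring with 2 hetero atoms and one six-membered aromatic ring of carbon only, so the expectation starts from compound 3 at 147 mL.min-1.g-1 and allows only a small move. The expected change is a 1.3-fold lower number from compound 3 to compound 4 (0.13 log units; within the scatter), which would lie within the scatter. For compound 4 the estimated value is 110 mL.min-1.g-1, with an expected range from 50 mL.min-1.g-1 to 230 mL.min-1.g-1.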

Compound 4, intrinsic clearance in microsomes: 99 mL.min-1.g-1
Compound 4: the middle estimate sits 1.1-fold (0.05 log units) above what was measured; the range from low to high includes it.
By their numbers in this assay, from the lowest: compound 2; then compounds 4 and 3 (each within the scatter of the next). At a limit, below all of these: compound 1.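

In this assay, the swap of 1,3-benzothiazol-5-yl for 2-methyl-1,3-benzoxazol-5-yl gives a 1.5-fold lower number from compound 3 to compound 4 (0.17 log units; within the scatter), so this first exchange of one two-ring group for another at this place, with oxygen in place of sulfur and an added methyl group, does not separate the two compounds. A second two-ring group now also stands clear of the single pyridin-4-yl ring, with a 3.2-fold higher number from compound 2 to compound 4 (0.50 log units; beyond the scatter), so that gap no longer rests on compound 3 alone. Against methoxy the step is an at least 7.0-fold higher number from compound 1 to compound 4 (0.84 log units; beyond the scatter), and its size is only a bound, since compound 1 stands at a limit of the assay: the limit of < 14 mL.min-1.g-1 in this assay, at which 1 of the 4 values shown sits.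

Two things changed at once from compound 3 to compound 4, so the compounds shown cannot split the share of the ring oxygen from that of the methyl group; plain 1,3-benzoxazol-5-yl, without the methyl, would be needed for that. On these data alone, it also stays open how removal would respond to a small non-ring group other than methoxy at this place, such as an amine or a carboxylic acid.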